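Swapping methoxy placement on the aryl arm of compound 2

This account rests on a few compounds, and the source may have more. Where it says the series, first, only, none or still open, it means among the compounds named here.

Measured compounds:
compound 1 `CC(=O)n1cc(/C=C(/C(=O)O)c2ccc(OCc3ccccc3)cc2)c2cc(OCc3ccccc3)ccc21`: 1410 nM
compound 2 `COc1cc(OC)cc(/C(=C\c2cn(C(C)=O)c3ccc(OCc4ccccc4)cc23)C(=O)O)c1`: 880 nM

In a functional assay on DU-145 cells (Homo sapiens) for cytotoxicity, read by MTT assay, with a stated time of 72 h (a higher number here means a weaker inhibitor, a lower number a stronger inhibitor), compound 2 gives 880 nM. Going by the values given here, the only other measured compound, compound 1, gives 1410 nM in this assay, and the two values lie within the usual scatter of each other, so neither can be called stronger. Compound 3 `COc1ccc(/C(=C\c2cn(C(C)=O)c3ccc(OCc4ccccc4)cc23)C(=O)O)cc1` differs from compound 2 in one place: 4-methoxyphenyl in place of 3,5-dimethoxyphenyl on a double-bonded chain carbon bound to a carbonyl carbon and a double-bonded chain carbon. Among the compounds with values here, no measured pair shows this change, so no step beyond the scatter is expected in either direction. Compound 3 is therefore estimated at 1000 nM, with a range from 400 nM to 2500 nM, an expected step of a 1.1-fold higher number from compound 2 to compound 3 (0.06 log units; within the scatter).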

Compound 3, half-maximal inhibitory concentration: 910 nM
Beside the measured number, compound 3's estimate is 1.1-fold (0.04 log units) above it; measured number inside the range.
By their numbers in this assay, from the lowest: compounds 2, 3 and 1 (each within the scatter of the next).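

In this assay the change from 3,5-dimethoxyphenyl to 4-methoxyphenyl on this double-bonded chain carbon leaves the number within the scatter (a 1.0-fold higher number from compound 2 to compound 3 (0.01 log units; within the scatter)), so these two methoxy patterns cannot be told apart here. A second one-place comparison, hydrogen in place of phenyl on a saturated chain carbon bound to an oxygen on an aromatic ring, also stays within the scatter (a 1.5-fold lower number from compound 1 to compound 3 (0.19 log units; within the scatter)). No measured evidence explains either result. On these data alone, whether an amine, a hydroxyl or a chlorine on this aryl ring would shift the number remains open.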